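Amide variation at the carbonyl carbon: compound 2 to compound 4

A few compounds are considered here, and "the series" means these few. Any claim that something is new, unique, unknown or untested is made for them only; others in the source may bear on it.

Three members of the series carry numbers in a functional assay on MIA PaCa-2 cells (Homo sapiens) for inhibition, read by MTT assay, with a stated time of 7 days; a lower number here means a stronger inhibitor, a higher number a weaker inhibitor. Compound 1 `O=C([C@@H]1CCCN(S(=O)(=O)c2ccc(S(=O)(=O)C3COC3)cc2)C1)N1CCC(F)(F)CC1` gives 110 nM. Compound 2 `CCN(CC)S(=O)(=O)c1ccc(S(=O)(=O)N2CCC[C@@H](C(=O)N3CCOCC3)C2)cc1` gives 350 nM, the second highest of the three numbers; it lies within the scatter of compound 3 `O=C([C@@H]1CCCN(S(=O)(=O)c2ccc(S(=O)(=O)N3CC[C@H](O)C3)cc2)C1)N1CCC(F)(F)CC1`, which gives 590 nM. From compound 1, whose number is lower, compound 2 lies beyond the scatter. Within the data shown here, the one measured step between compounds differing in a single place is a 5.4-fold higher number from compound 1 to compound 3 (0.73 log units; beyond the scatter), and that change sits on a sulfonyl sulfur, not on the carbonyl carbon.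

Compound 4 `CCN(CC)S(=O)(=O)c1ccc(S(=O)(=O)N2CCC[C@@H](C(=O)N3CC[C@H](OC)C3)C2)cc1` differs from compound 2 in one place: 3-methoxypyrrolidin-1-yl in place of morpholin-4-yl on a carbonyl carbon. Among the measured compounds shown here, no measured step touches the carbonyl carbon, so nothing speaks directly to this change; the shared core and the sulfonyl side of compound 2 are kept unchanged. For the measured compounds named here, with no comparable step to lean on, the expectation for this assay is a move that stays within the scatter, a 1.2-fold lower number from compound 2 to compound 4 (0.07 log units; within the scatter), with no firm direction. Compound 4 is therefore estimated at 300 nM, with a range from 120 nM to 750 nM.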

Compound 4, half-maximal inhibitory concentration: 2460 nM
Beside the measured number, compound 4's estimate is 8.2-fold (0.91 log units) below it; measured number above the stated range.
By their numbers in this assay, from the lowest: compound 1; then compounds 2 and 3 (each within the scatter of the next); then compound 4.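

The amide on the carbonyl carbon is not a neutral place in this assay: 3-methoxypyrrolidin-1-yl in place of morpholin-4-yl gives a 7.0-fold higher number from compound 2 to compound 4 (0.85 log units; beyond the scatter), with the rest of compound 2 unchanged, so this position responds as clearly as the sulfonyl sulfur does in a 5.4-fold higher number from compound 1 to compound 3 (0.73 log units; beyond the scatter). The change bundles several differences: a five-membered ring replaces a six-membered one, the ring holds one hetero atom instead of two, the oxygen now sits in a methoxy group, and a defined stereocentre enters. The step alone cannot assign the rise to any one of these, and no measurement bearing on its cause is at hand.

Still open, going by these compounds, is which of these differences carries the step; piperidin-1-yl, unsubstituted pyrrolidin-1-yl and the opposite stereoisomer of 3-methoxypyrrolidin-1-yl on the same carbonyl carbon would begin to separate them. Among these compounds, also open is whether the step holds on another sulfonyl side, such as the oxetan-3-yl of compound 1, as this amide change is seen only with the sulfonyl side of compound 2.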